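Swapping methyl for chloro: an estimate for compound 4

A few compounds are considered here, and "the series" means these few. Any claim that something is new, unique, unknown or untested is made for them only; others in the source may bear on it.

Of the compounds shown here, three have been measured so far in a functional assay on thoracic aorta (Rattus norvegicus, strain Wistar), with a stated time of 15 min (a higher number here means that more compound is needed for the effect, a lower number that less compound is needed), to date. Compound 1 (`COc1ccc(F)cc1C(C)NC(=O)N(C)S(=O)(=O)c1ccc(Cl)cc1`) gives 12600 nM there, compound 2 (`Cc1ccc(S(=O)(=O)N(C)C(=O)NC(C)c2cc(Br)ccc2OCc2ccccc2)cc1`) gives 67100 nM there, and compound 3 (`Cc1ccc(S(=O)(=O)N(C)C(=O)NC(C)c2cc(C)ccc2OCc2ccccc2)cc1`) gives 181000 nM as the highest number of the three.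

Compound 4 (`Cc1ccc(OCc2ccccc2)c(C(C)NC(=O)N(C)S(=O)(=O)c2ccc(Cl)cc2)c1`) has not been measured yet. It differs from compound 3 in one place (chloro in place of methyl on an aromatic carbon): chloro in place of methyl on an aromatic carbon, para to a large group, so that 4-methylphenyl becomes 4-chlorophenyl.

The closest measured change is a related swap, in the opposite sense and elsewhere in the molecule. That change, methyl in place of bromo on an aromatic carbon, gave a 2.7-fold higher number from compound 2 to compound 3 (0.43 log units; beyond the scatter) in a modest move. Compound 1 also carries 4-chlorophenyl, but the rest of it differs too, so it is only a loose guide. With so little evidence, a halogen replacing methyl is expected to lower the number slightly, perhaps without clearing the usual scatter. The expected change is a 1.9-fold lower number from compound 3 to compound 4 (0.28 log units; within the scatter) in this assay at most modest in size. Compound 4 is estimated at 95000 nM within an expected range of 35000 nM to 220000 nM in this assay at this stage.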

Compound 4, half-maximal effective concentration: 142000 nM
The estimate for compound 4 lay 1.5-fold (0.17 log units) below the measured number, and the stated range covers the measured number.
By their numbers in this assay, from the lowest: compound 1; then compound 2; then compounds 4 and 3 (each within the scatter of the next).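

In this assay, chloro in place of methyl on the aromatic carbon para to a large group, which turns 4-methylphenyl into 4-chlorophenyl, gives a 1.3-fold lower number from compound 3 to compound 4 (0.11 log units; within the scatter), so this swap at this position produces no change that can be told apart from the ordinary spread of repeated measurements. Within the data shown here, the only earlier step between closely matched compounds, a 2.7-fold higher number from compound 2 to compound 3 (0.43 log units; beyond the scatter), did clear that spread, but it exchanged methyl with a different halogen elsewhere in the molecule, so a result at one position does not carry over to another. Nothing measured on these compounds accounts for why this position tolerates the exchange of methyl and chloro so quietly.

On these data alone, with only methyl and chloro compared here, it remains open whether a group of another kind on the same carbon, such as an amine or a carboxylic acid, would shift the number clearly in either direction. As far as these compounds go, it is also open whether the exchange of methyl and chloro at this position would stay as small on a different core.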